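From Compound 3 to Compound 4: Little Change Expected

The source may report more compounds than this note shows. Statements on the series, on what has been measured and on what is new or still open speak of the compounds shown alone.

In a functional assay on MCF7 cells (Homo sapiens) for inhibition, read by MTT assay, with a stated time of 48 h (on this read-out lower numbers stand for stronger inhibition and higher numbers for weaker inhibition), compound 1 `CCOC(=O)C1=C(N/N=C(/C#N)C(=O)OCC)Nc2[nH]nc(C)c2C1c1ccc(N(C)C)cc1` gives 35600 nM, compound 2 `CCOC(=O)C1=C(N/C=N/c2ccccn2)Nc2[nH]nc(C)c2C1c1ccc(N(C)C)cc1` gives 37300 nM and compound 3 `CCOC(=O)C1=C(N/N=C(/C(=O)Br)c2ccc(Cl)cc2)Nc2[nH]nc(C)c2C1c1ccc(N(C)C)cc1` gives 46300 nM. Compound 3 therefore stands within the scatter of both others. Compound 4 `CCOC(=O)C1=C(N/C=N/c2ccc([N+](=O)[O-])cc2)Nc2[nH]nc(C)c2C1c1ccc(N(C)C)cc1` differs from compound 3 by a group of 11 heavy atoms (7 carbon, 2 nitrogen, 2 oxygen; one six-membered aromatic ring of carbon only) in place of a group of 12 heavy atoms (8 carbon, 1 nitrogen, 1 oxygen, 1 chlorine, 1 bromine; one six-membered aromatic ring of carbon only), on an amine nitrogen. Among the compounds with values here, three measured steps bear on this exchange, all on the same amine nitrogen: a 1.3-fold higher number from compound 1 to compound 3 (0.11 log units; within the scatter), a 1.2-fold higher number from compound 2 to compound 3 (0.09 log units; within the scatter) and a 1.0-fold higher number from compound 1 to compound 2 (0.02 log units; within the scatter). Each of them stayed within the scatter, although the groups exchanged differ considerably. No step beyond the scatter is therefore expected in this assay. The estimated step is a 1.2-fold lower number from compound 3 to compound 4 (0.06 log units; within the scatter). For compound 4, the expected value is 40000 nM, with an estimated range of 20000 nM to 80000 nM.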

Compound 4, half-maximal inhibitory concentration: 58600 nM
For compound 4 the middle estimate is 1.5-fold (0.17 log units) below the measured one, and the stated range covers the measured number.
By their numbers in this assay, from the lowest: compounds 1, 2, 3 and 4 (each within the scatter of the next).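

In this assay the amine nitrogen also takes a nitro-bearing phenyl group with no step beyond the scatter, as shown by a 1.3-fold higher number from compound 3 to compound 4 (0.10 log units; within the scatter) and by a 1.6-fold higher number from compound 1 to compound 4 (0.22 log units; within the scatter). The closest comparison, 4-nitrophenyl in place of pyridin-2-yl on a double-bonded nitrogen, likewise stays within it, with a 1.6-fold higher number from compound 2 to compound 4 (0.20 log units; within the scatter). Nothing available here explains these steps. Going by these compounds, whether a carboxylic acid or an amine in place of the nitro group, or a change elsewhere on the shared core, would give a step beyond the scatter remains open.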